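This account rests on a few compounds, and the source may have more. Where it says the series, first, only, none or still open, it means among the compounds named here.

Compounds measured in an ADME assay on a cell-free system (plasma, Homo sapiens) for metabolic stability, with Plasma (Rattus norvegicus) as the target, read by HPLC, at pH 7.4; on this read-out higher numbers stand for a longer-lived compound and lower numbers for a shorter-lived compound:
Compound 1 `CC(=O)Oc1ccccc1C(=O)O[C@H]1CO[C@H]2[C@@H]1OC[C@H]2OC(=O)c1ccccc1O` gives 0.019 h
Compound 2 `CC(=O)Oc1ccccc1C(=O)O[C@H]1CO[C@H]2[C@@H]1OC[C@H]2OC(=O)c1ccc(O)cc1` gives 0.0198 h
Compound 3 `CCOc1cc(OCC)cc(C(=O)O[C@@H]2CO[C@H]3[C@@H]2OC[C@@H]3OC(=O)c2ccccc2OC(C)=O)c1` gives 0.0283 h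

Compound 2 sits among these three numbers with neither neighbour apart from it beyond the scatter: a 1.0-fold higher number from compound 1 to compound 2 (0.02 log units; within the scatter) and a 1.4-fold higher number from compound 2 to compound 3 (0.16 log units; within the scatter). Compound 4 `CC(=O)Oc1ccccc1C(=O)O[C@H]1CO[C@H]2[C@@H]1OC[C@H]2OC(=O)c1ccncc1` differs from compound 2 by pyridin-4-yl in place of 4-hydroxyphenyl on a carbonyl carbon. The three measured steps all exchange the same aryl group on this carbonyl carbon, and each stayed within the scatter, including a 1.5-fold higher number from compound 1 to compound 3 (0.17 log units; within the scatter). No change of that aryl group has so far moved this assay beyond its scatter, so compound 4 is expected to show a 1.0-fold higher number from compound 2 to compound 4 (0.00 log units; within the scatter), with no movement beyond the scatter. Compound 4 is therefore estimated at 0.02 h in this assay, within a range of 0.01 h to 0.04 h.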

Compound 4, half-life: 0.0055 h
For compound 4 the middle estimate is 3.6-fold (0.56 log units) above the measured one; the measured number lies below the stated range.
By their numbers in this assay, from the lowest: compound 4; then compounds 1, 2 and 3 (each within the scatter of the next).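

In this assay this place on a carbonyl carbon proves able to move the half-life beyond the scatter, with pyridin-4-yl giving the first such steps (a 3.6-fold lower number from compound 2 to compound 4 (0.56 log units; beyond the scatter); a 5.1-fold lower number from compound 3 to compound 4 (0.71 log units; beyond the scatter); a 3.5-fold lower number from compound 1 to compound 4 (0.54 log units; beyond the scatter)). The three phenyl-bearing compounds, compound 1, compound 2 and compound 3, stay within the scatter of one another, so compound 4 stands apart from all of them at the low end. Nothing available explains this drop. On these data alone, whether pyridin-3-yl or an aminophenyl on this carbonyl carbon would fall as low as compound 4 remains open.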